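Acetoxy to hydroxy on two cores: cytotoxicity notes

A few compounds are considered here, and "the series" means these few. Any claim that something is new, unique, unknown or untested is made for them only; others in the source may bear on it.

Measured so far in an ADME assay on DU-145 cells (Homo sapiens) for cytotoxicity, read by MTT assay, with a stated time of 72 h; a lower number here means a stronger inhibitor, a higher number a weaker inhibitor:
compound 1 `COc1ccc(C2=C(c3cc(OC)c(OC)c(OC)c3)C(=O)C(OC(C)=O)C2)cc1F` gives 16 ug/mL.
compound 2 `COc1ccc(C2=C(c3cc(OC)c(OC)c(OC)c3)C(=O)C(O)C2)cc1F` gives 27 ug/mL.
compound 3 `CC(=O)OC1C/C(=N/O)C(c2ccccc2)=C1c1ccccc1` gives > 100 ug/mL, which is a limit of the assay and not a number.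

From compound 1 to compound 2 the change is hydrogen in place of acetyl on an oxygen on a saturated carbon, and the step in this assay is a 1.7-fold higher number from compound 1 to compound 2 (0.23 log units; within the scatter). For compound 3 the evidence is only (the limit of > 100 ug/mL in this assay, at which 1 of the 3 values shown sits). Compound 4 `O/N=C1/CC(O)C(c2ccccc2)=C1c1ccccc1` is not yet measured; it differs from compound 3 by hydrogen in place of acetyl on an oxygen on a saturated carbon, the same change as from compound 1 to compound 2, at a place described in the same words. The difference between the core of compound 1 and the core of compound 3 is not broken down here. Since the measured step was a 1.7-fold higher number from compound 1 to compound 2 (0.23 log units; within the scatter), the expected step that the limit leaves unreadable from compound 3 to compound 4 is likewise small. Compound 4 is therefore estimated at 120 ug/mL, between 40 ug/mL and 300 ug/mL, most likely returning only a limit again.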

Compound 4, half-maximal inhibitory concentration: > 100 ug/mL
Compound 4 gave a limit, no number; the forecaster's own chance of this, stated with the estimate: 75%; the middle value does not contradict the limit.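

Compound 3 and compound 4 both stand at a limit, so no step between them can be read: the limit of > 100 ug/mL in this assay, at which 2 of the 4 values shown sit.

The compounds shown leave open whether acetoxy to hydroxy shifts cytotoxicity at all on the core of compound 3.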